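The source may hold more compounds than are shown below. What is called first, only, known or untested is meant among the compounds shown, and "the series" means these compounds.

For the measured compounds named here, in a functional assay on cells (Cancer cell lines, Homo sapiens) for cytotoxicity, read by sulforhodamine B assay, with a stated time of 48 h (on this read-out higher numbers stand for weaker inhibition of growth and lower numbers for stronger inhibition of growth), compound 3 `O=C1N=C(N2N=C(c3ccccc3)CC2c2ccc(Cl)cc2)S/C1=C1/C(=O)Nc2ccccc21` gives 190 nM, the lowest of the three numbers so far. Compound 2 `COc1ccc(C2CC(c3ccccc3)=NN2C2=NC(=O)/C(=C3\C(=O)Nc4ccccc43)S2)cc1` gives 1620 nM and compound 1 `O=C1N=C(N2N=C(c3ccccc3)CC2c2ccccc2O)S/C1=C1/C(=O)Nc2ccccc21` gives 2130 nM. The steps of an 11-fold lower number from compound 1 to compound 3 (1.05 log units; beyond the scatter) and an 8.5-fold lower number from compound 2 to compound 3 (0.93 log units; beyond the scatter) both ran down to compound 3, whereas a 1.3-fold lower number from compound 1 to compound 2 (0.12 log units; within the scatter) stayed within the scatter. Compound 4 `CN(C)c1ccc(C2CC(c3ccccc3)=NN2C2=NC(=O)/C(=C3\C(=O)Nc4ccccc43)S2)cc1` carries dimethylamino in place of chloro on an aromatic carbon. Going by the values given here, the one measured step that bears on this is an 8.5-fold lower number from compound 2 to compound 3 (0.93 log units; beyond the scatter), where methoxy gave way to chloro on an aromatic carbon of a six-membered aromatic ring of carbon only, para to a large group. Running that exchange the other way, now to dimethylamino, is expected to raise the number in this assay, and compound 4 is estimated at 1000 nM, with a range of 300 nM to 3500 nM. The step expected is a 5.3-fold higher number from compound 3 to compound 4 (0.72 log units; beyond the scatter).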

Compound 4, concentration for 50% growth inhibition: 1110 nM
Compound 4: middle estimate off by 1.1-fold (0.05 log units), on the low side, within the range that was stated.
By their numbers in this assay, from the lowest: compound 3; then compounds 4, 2 and 1 (each within the scatter of the next).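

In this assay the low number does not survive a second replacement of chloro on this aromatic carbon, para to a large group: dimethylamino gives a 5.8-fold higher number from compound 3 to compound 4 (0.77 log units; beyond the scatter) in the same direction as methoxy. Dimethylamino and methoxy are not separated, with a 1.5-fold lower number from compound 2 to compound 4 (0.16 log units; within the scatter) as their step, and a 1.9-fold lower number from compound 1 to compound 4 (0.28 log units; within the scatter) likewise leaves 4-(dimethylamino)phenyl level with 2-hydroxyphenyl, so compound 3 alone stands apart from the other three. No measurement on hand explains this difference.

On these data alone, whether the low number is particular to chloro remains open; bromo, fluoro or trifluoromethyl on the same aromatic carbon would test that.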